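This account rests on a few compounds, and the source may have more. Where it says the series, first, only, none or still open, it means among the compounds named here.

In a functional assay on the whole organism for inhibition, with Mythimna separata as the target, with a stated time of 5 days (on this read-out higher numbers stand for an effect only at larger amounts of compound and lower numbers for an effect already at smaller amounts), compound 1 `CC(C)(C)n1ncc(OCc2nnc(-c3ccc(Cl)cc3)o2)c(Cl)c1=O` gives 1900 nM, the lowest number among the three compounds measured. Compound 2 `CC(C)(C)n1ncc(OCc2nnc(-c3ccc(C(F)(F)F)cc3)o2)c(Cl)c1=O` gives 33800 nM, and compound 3 `CCCCn1ncc(OCc2nnc(-c3ccc(Cl)cc3)o2)c(Cl)c1=O` gives 223000 nM. Compound 4 `CC(C)(C)n1ncc(OCc2nnc(-c3ccc(Cl)cc3F)o2)c(Cl)c1=O` differs from compound 1 by fluoro in place of hydrogen on an aromatic carbon; cut one bond further out, the difference reads 4-chlorophenyl to 4-chloro-2-fluorophenyl. Within the data shown here, no measured step repeats this change. The step of an 18-fold higher number from compound 1 to compound 2 (1.25 log units; beyond the scatter) shows that changing a group on this same ring can move this assay a long way, while the step of a 120-fold higher number from compound 1 to compound 3 (2.07 log units; beyond the scatter) concerns another part of the molecule. For compound 4 a modest step in this assay is expected, a 1.6-fold higher number from compound 1 to compound 4 (0.20 log units; within the scatter), giving an estimate of 3000 nM with a range from 800 nM to 12000 nM.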

Compound 4, half-maximal effective concentration: 10400 nM
For compound 4 the middle estimate is 3.5-fold (0.54 log units) below the measured one; low and high end bracket the measured number.
By their numbers in this assay, from the lowest: compound 1; then compound 4; then compound 2; then compound 3.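

In this assay, the step of a 5.5-fold higher number from compound 1 to compound 4 (0.74 log units; beyond the scatter) comes from adding a single fluoro, just one heavy atom, ortho to a large group on the 4-chlorophenyl ring. The read-out therefore responds not only to replacing the chloro group, as in compound 2, but also to changing a ring carbon that carries only hydrogen in compound 1. Nothing available explains this rise. From the compounds shown here alone, whether a methoxy group or an amine at this carbon would give a lower or higher number remains open. So does whether fluoro elsewhere on this ring would have a similar effect.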